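Moving the methoxy around the thiophene ring of a sulfonylurea

This account rests on a few compounds, and the source may have more. Where it says the series, first, only, none or still open, it means among the compounds named here.

Measured compounds:
- compound 1, `O=C(Nc1ccc(Cl)cc1)NS(=O)(=O)c1cccs1`: 16%
- compound 2, `COc1ccc(S(=O)(=O)NC(=O)Nc2ccc(Cl)cc2)s1`: 93%
- compound 3, `CCc1ccc(S(=O)(=O)NC(=O)Nc2ccc(Cl)cc2)o1`: 57%

These three share a common core and differ only in the aromatic ring attached to the sulfonyl sulfur. In a functional assay on the whole organism (6C3HED cells, Mus musculus) for inhibition, at a dose of 150 mg/kg by the oral route (on this read-out higher numbers stand for more inhibition at the one dose given (going by the name of the read-out) and lower numbers for less inhibition), compound 3 stands second highest of the three numbers: compound 2 lies well above it, and compound 1 well below it, both beyond the scatter.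

Compound 4, `COc1csc(S(=O)(=O)NC(=O)Nc2ccc(Cl)cc2)c1`, has not yet been measured. It differs from compound 3 in one place: 4-methoxythiophen-2-yl in place of 5-ethylfuran-2-yl on a sulfonyl sulfur

For the measured compounds named here, two measured steps bear on this change. Replacing the plain thiophen-2-yl of compound 1 with 5-ethylfuran-2-yl gave a number 41 percentage points higher from compound 1 to compound 3 (beyond the scatter), and replacing the 5-methoxythiophen-2-yl of compound 2 with the same group gave a number 36 percentage points lower from compound 2 to compound 3 (beyond the scatter). The large gain of a number 77 percentage points higher from compound 1 to compound 2 (beyond the scatter) shows that a methoxy on the thiophene ring mattered a great deal in that pair. Going by the values given here, compound 4 carries a methoxythiophene again, though as 4-methoxythiophen-2-yl rather than 5-methoxythiophen-2-yl, so no measured pair shows exactly this arrangement. The expectation is therefore a moderate rise, a number 13 percentage points higher from compound 3 to compound 4 (beyond the scatter), with wide uncertainty. Compound 4 is estimated at 70%, between 40% and 95%.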

Compound 4, a percentage reported as inhibition, in the whole organism at one dose (the size of the read-out at that dose, not a potency): 36%
Compound 4: middle estimate off by 34 percentage points, on the high side; measured number below the stated range.
By their numbers in this assay, from the lowest: compound 1; then compound 4; then compound 3; then compound 2.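

In this assay, moving the methoxy from 5-methoxythiophen-2-yl to 4-methoxythiophen-2-yl gives a number 57 percentage points lower from compound 2 to compound 4 (beyond the scatter), so the large gain seen earlier belongs to one particular placement of the methoxy and not simply to its presence on the thiophene. The 4-methoxythiophen-2-yl group still improves on the plain thiophen-2-yl, with a number 20 percentage points higher from compound 1 to compound 4 (beyond the scatter), but this gain is much smaller than a number 77 percentage points higher from compound 1 to compound 2 (beyond the scatter). A methoxythiophene on the sulfonyl sulfur therefore does not by itself beat the 5-ethylfuran-2-yl group: exchanging that furan for 4-methoxythiophen-2-yl gives a number 21 percentage points lower from compound 3 to compound 4 (beyond the scatter), whereas compound 2 stands above compound 3.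

Why the two methoxy placements differ so much remains unexplained, since no measurement here bears on the cause. Also open, on these data alone, is whether an ethoxy, a hydroxy or an amine in place of the methoxy would keep the higher number of compound 2 or fall towards that of compound 4, and so whether the effect is specific to methoxy at all.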